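Moving the hydroxyl on a shared pyridine-free core: compound 2 to compound 3

The source may report more compounds than this note shows. Statements on the series, on what has been measured and on what is new or still open speak of the compounds shown alone.

Of the compounds shown here, two have been measured so far in a functional assay on T47D cells (Homo sapiens) for cytotoxicity, read by CCK-8 assay and cell counting, with a stated time of 2 days; a lower number here means a stronger inhibitor, a higher number a weaker inhibitor. Compound 1, `Oc1ccc(-c2cc(-c3ccc(Cl)cc3)nc(-c3ccsc3)c2)cc1`, gives 5490 nM in this assay. Compound 2, `Oc1cccc(-c2cc(-c3ccccc3)nc(-c3ccc(Cl)cc3)c2)c1`, gives 11300 nM, the highest of the two numbers; its nearest neighbour is compound 1, whose number is lower by more than the usual scatter.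

The next compound, compound 3, `Oc1ccc(-c2cc(-c3ccccc3)nc(-c3ccc(Cl)cc3)c2)cc1`, has not been measured. It differs from compound 2 in one place only: 4-hydroxyphenyl in place of 3-hydroxyphenyl on an aromatic carbon. The two share the same atoms, joined differently; the hydroxyl simply moves within the same phenyl ring.

Among the compounds with values here, no step between measured compounds involves this change, so no measured step can be used directly. Compound 1 carries the same 4-hydroxyphenyl group as compound 3, though its other groups are placed differently, and compound 1 gives 5490 nM. On that basis a modest step to a lower number in this assay, from compound 2 to compound 3, is expected: a 1.6-fold lower number from compound 2 to compound 3 (0.21 log units; within the scatter). The estimate for compound 3 in this assay is 7000 nM, within a range from 3000 nM to 16000 nM.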

Compound 3, half-maximal inhibitory concentration: 4270 nM
Beside the measured number, compound 3's estimate is 1.6-fold (0.21 log units) above it; low and high end bracket the measured number.
By their numbers in this assay, from the lowest: compounds 3 and 1 (each within the scatter of the next); then compound 2.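

In this assay, moving the hydroxyl within the same phenyl ring gives a 2.6-fold lower number from compound 2 to compound 3 (0.42 log units; beyond the scatter), so on this shared core the position of that one group separates two compounds with identical atoms by more than the scatter. At this carbon, opposite the ring nitrogen, 4-hydroxyphenyl therefore reads lower than 3-hydroxyphenyl, a comparison the earlier pair of compounds, which differ in more than one place, could not make. The second step, phenyl in place of thiophen-3-yl on an aromatic carbon, is a 1.3-fold lower number from compound 1 to compound 3 (0.11 log units; within the scatter), which lies within the scatter and leaves those two groups unseparated, and no measurement at hand accounts for either result.

The hydroxyl shift is shown on a single pair, so whether it would give a similar step with thiophen-3-yl in place of phenyl on the shared core remains open. How a methoxy group or an amine would read in place of the hydroxyl on that phenyl ring also remains open, so the compounds shown cannot say whether the hydroxyl itself matters or only where the ring carries a substituent.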